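Thiazole for furan on the fluorophenyl core

A few compounds are considered here, and "the series" means these few. Any claim that something is new, unique, unknown or untested is made for them only; others in the source may bear on it.

Three compounds of this series have been run in a functional assay on MCF7 cells (Homo sapiens) for inhibition, with a stated time of 96 h; on this read-out higher numbers stand for weaker inhibition and lower numbers for stronger inhibition. Compound 1 `COc1cc(C(=O)c2cn(-c3cccc(C)c3)cc2-c2ccoc2)cc(OC)c1OC` gives 21 nM. Compound 2 `COc1cc(C(=O)c2cn(-c3cccc(C)c3)cc2-c2nccs2)cc(OC)c1OC` gives 20 nM, and compound 3 `COc1cc(C(=O)c2cn(-c3ccc(F)cc3)cc2-c2ccoc2)cc(OC)c1OC` gives 15 nM. All three values sit within the scatter of one another, so no order among them can be claimed.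

Compound 2 differs from compound 1 in one place: 1,3-thiazol-2-yl in place of furan-3-yl on an aromatic carbon The step was a 1.1-fold lower number from compound 1 to compound 2 (0.02 log units; within the scatter).

Compound 3 differs from compound 1 only in the group on the ring nitrogen: 4-fluorophenyl in place of 3-methylphenyl on an aromatic nitrogen The step was a 1.4-fold lower number from compound 1 to compound 3 (0.15 log units; within the scatter).

Compound 4 `COc1cc(C(=O)c2cn(-c3ccc(F)cc3)cc2-c2nccs2)cc(OC)c1OC` has not yet been measured in this assay. Among the compounds with values here, it differs from compound 3 in one place: 1,3-thiazol-2-yl in place of furan-3-yl on an aromatic carbon This is the same kind of change as the one from compound 1 to compound 2, on the same aromatic carbon, two ring bonds from the ring nitrogen and next to the ring atom that bears a large group. The place differs only in what the ring nitrogen carries: a 4-fluorophenyl group in compound 3 and compound 4 against a 3-methylphenyl group in compound 1 and compound 2.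

Within the data shown here, the step from compound 3 to compound 4 is expected to be a 1.1-fold lower number from compound 3 to compound 4 (0.03 log units; within the scatter), resting on the one earlier example of this change, a 1.1-fold lower number from compound 1 to compound 2 (0.02 log units; within the scatter), which stayed within the scatter. Compound 4 is therefore estimated at 14 nM, with the likely range from 7 nM to 28 nM.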

Compound 4, half-maximal inhibitory concentration: 22 nM
Compound 4: middle estimate off by 1.6-fold (0.20 log units), on the low side; measured number inside the range.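

In this assay, the replacement of furan-3-yl by 1,3-thiazol-2-yl can now be read on two cores, and the new step, a 1.5-fold higher number from compound 3 to compound 4 (0.17 log units; within the scatter), agrees with the earlier one: the same change on two cores in this assay, a 1.1-fold lower number (0.02 log units; within the scatter) from compound 1 to compound 2 and a 1.5-fold higher number (0.17 log units; within the scatter) from compound 3 to compound 4, 1.5-fold (0.19 log units) apart, within the scatter of two such steps. The exchange of 3-methylphenyl for 4-fluorophenyl on the ring nitrogen, now also read on two cores as a 1.1-fold higher number from compound 2 to compound 4 (0.04 log units; within the scatter), gives the same picture: the same change on two cores in this assay, a 1.4-fold lower number (0.15 log units; within the scatter) from compound 1 to compound 3 and a 1.1-fold higher number (0.04 log units; within the scatter) from compound 2 to compound 4, 1.5-fold (0.19 log units) apart, within the scatter of two such steps. Across these four compounds, each change carries from one core to the other with no measurable shift in the read-out, but this does not show that either change is truly without effect, that the two steps of a pair differ in direction, or that the same would hold on any other core.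

The compounds shown carry only aromatic rings on the aromatic carbon and on the ring nitrogen, so the result says nothing about an amine or a carboxylic acid on that carbon, or a longer alkyl chain on the nitrogen. As far as these compounds go, whether such groups would produce a step beyond the scatter, and whether that step would then carry between these cores, remains open.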